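Replacing 3,4,5-trihydroxyphenyl with 4-nitrophenyl in compound 1

The source may hold more compounds than are shown below. What is called first, only, known or untested is meant among the compounds shown, and "the series" means these compounds.

In a physicochemical assay, read by spectrophotometry, with a stated time of 6 min (on this read-out higher numbers stand for weaker inhibition and lower numbers for stronger inhibition), compound 1 `O=C(CCCc1nc2ccccc2c(=O)[nH]1)N/N=C/c1cc(O)c(O)c(O)c1` gives 40000000 nM as its half-maximal inhibitory concentration. Going by the values given here, compound 2 `COc1cc(/C=N/NC(=O)CCc2nc3ccccc3c(=O)[nH]2)cc(OC)c1OC` gives 55000000 nM in the same measurement, and these two numbers lie within the usual scatter of each other, so compound 1 stands level with the only other compound measured.

Compound 3 `O=C(CCCc1nc2ccccc2c(=O)[nH]1)N/N=C/c1ccc([N+](=O)[O-])cc1` has not yet been measured. It differs from compound 1 by a single change, 4-nitrophenyl in place of 3,4,5-trihydroxyphenyl on a carbon with a double bond to nitrogen. Among the compounds with values here, no measured pair differing in one place is available, so the data do not show directly what such a change does in this assay here. A small step towards a higher number, meaning weaker inhibition, is expected, and it may not go beyond the scatter. The closeness of compound 2 at 55000000 nM to compound 1 at 40000000 nM offers no sign of a wide spread. The estimated size of the move is a 1.5-fold higher number from compound 1 to compound 3 (0.18 log units; within the scatter) on this reading. For compound 3 the estimated value is 60000000 nM with an expected range from 25000000 nM to 150000000 nM in this assay.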

Compound 3, half-maximal inhibitory concentration: 270000000 nM
Beside the measured number, compound 3's estimate is 4.5-fold (0.65 log units) below it, and the stated range ends below it.
By their numbers in this assay, from the lowest: compounds 1 and 2 (each within the scatter of the next); then compound 3.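

In this assay, the group on a carbon with a double bond to nitrogen proves able to move the read-out: 4-nitrophenyl in place of 3,4,5-trihydroxyphenyl gives a 6.8-fold higher number from compound 1 to compound 3 (0.83 log units; beyond the scatter), which means weaker inhibition by more than the scatter. Going by these compounds alone, compounds 1 and 2 differ in more than one place and could not show this, so this pair is the first in which the effect of a single change can be read. Within the data shown here, the two groups have the same number of heavy atoms and each holds one six-membered aromatic ring of carbon only, whereas the hydrogen-bond donors of 3,4,5-trihydroxyphenyl have no counterpart in 4-nitrophenyl, but no measurement at hand ties the step to this or any other difference between them.

Still open, on these data alone, is whether unsubstituted phenyl, or a phenyl ring carrying a single hydroxyl, an amine or a carboxylic acid, would read closer to compound 1 or to compound 3. As far as these compounds go, it also remains open whether the same change would give a step of similar size on the chain carried by compound 2.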